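An Aryl Group in Place of Methyl on the Core

The source may report more compounds than this note shows. Statements on the series, on what has been measured and on what is new or still open speak of the compounds shown alone.

Measured compounds:
compound 1, `CC1C(=O)N(C)c2cnc(Nc3ccc(S(N)(=O)=O)cc3)nc2N1C`, 313 nM
compound 2, `CC(C)C1C(=O)N(C)c2cnc(Nc3ccc(S(N)(=O)=O)cc3)nc2N1C`, 254 nM
compound 3, `CCc1ccccc1C1C(=O)N(C)c2cnc(Nc3ccc(S(N)(=O)=O)cc3)nc2N1C`, 51 nM

In an assay on Sf9 cells for inhibition of serine/threonine-protein kinase 4 (Homo sapiens), read by luminescence and ADP-Glo, with a stated time of 1 h, in the presence of a further agent that is not named here (on this read-out higher numbers stand for weaker inhibition and lower numbers for stronger inhibition), compound 1 stands highest of the three numbers. Its nearest neighbour is compound 2, with a 1.2-fold lower number from compound 1 to compound 2 (0.09 log units; within the scatter); the furthest is compound 3, with a 6.1-fold lower number from compound 1 to compound 3 (0.79 log units; beyond the scatter). Compound 4, `CN1C(=O)C(c2ccccc2Br)N(C)c2nc(Nc3ccc(S(N)(=O)=O)cc3)ncc21`, carries the change (2-bromophenyl in place of methyl on a saturated ring carbon). Within the data shown here, the steps that bear on it are those that place an aryl group on the same saturated ring carbon: a 6.1-fold lower number from compound 1 to compound 3 (0.79 log units; beyond the scatter) and a 5.0-fold lower number from compound 2 to compound 3 (0.70 log units; beyond the scatter), both beyond the scatter and both modest. The 2-bromophenyl group of compound 4 is expected to behave like the 2-ethylphenyl group of compound 3, so a downward step of similar size, a 4.5-fold lower number from compound 1 to compound 4 (0.65 log units; beyond the scatter), is expected in this assay. Compound 4 is therefore estimated at 70 nM, with a range from 30 nM to 180 nM.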

Compound 4, half-maximal inhibitory concentration: 57 nM
For compound 4 the middle estimate is 1.2-fold (0.09 log units) above the measured one, and the stated range covers the measured number.
By their numbers in this assay, from the lowest: compounds 3 and 4 (each within the scatter of the next); then compounds 2 and 1 (each within the scatter of the next).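

In this assay a second aryl group on the saturated ring carbon also goes with a lower number, both against methyl (a 5.5-fold lower number from compound 1 to compound 4 (0.74 log units; beyond the scatter)) and against isopropyl (a 4.5-fold lower number from compound 2 to compound 4 (0.65 log units; beyond the scatter)). Bromo in place of ethyl on the aromatic carbon (a 1.1-fold higher number from compound 3 to compound 4 (0.05 log units; within the scatter)) leaves the number within the scatter, so the drop is not peculiar to the 2-ethylphenyl group. Nothing measured here explains the drop.

Still open, from the compounds shown here alone, is whether an unsubstituted phenyl or a benzyl group on this carbon would give numbers like those of compound 3 and compound 4. Also open, going by these compounds, is how a methoxy group or a carboxylic acid on the aryl ring would read.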